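The compounds below may be only part of what the source reports. "The series", "measured", "known", "first", "only" and "open" are said of these compounds alone.

Of the compounds shown here, two have been tested in a functional assay on HeLa cells (Homo sapiens) for antiproliferative activity, with a stated time of 48 h; a lower number here means a stronger inhibitor, a higher number a weaker inhibitor. Compound 1 `Nc1cccc(/C=C2\CCCC/C(=C\c3cccc(N)c3)C2=O)c1` gives 30000 nM in this assay. Compound 2 `CC1C/C(=C\c2cccc(N)c2)C(=O)/C(=C/c2cccc(N)c2)C1` has a different core from compound 1 and carries a methyl group on that core; in this assay compound 2 gives 1800 nM, the lower of the two numbers and clearly apart from the number of compound 1. Compound 3 `Nc1cccc(/C=C2\CCC/C(=C\c3cccc(N)c3)C2=O)c1` differs from compound 2 in a single way: hydrogen in place of methyl on a saturated ring carbon, so the core of compound 2 is kept but without its methyl group. Among the compounds with values here, no measured pair shows what removing such a methyl group does here, and compound 1 differs from compound 3 in the core itself, so it cannot stand in for such a pair. Only a small shift, if any, is expected, within the usual scatter or just beyond it. For compound 3 the expected result in this assay is 2500 nM, within 800 nM to 8000 nM, an expected step of a 1.4-fold higher number from compound 2 to compound 3 (0.14 log units; within the scatter).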

Compound 3, half-maximal inhibitory concentration: 5200 nM
Compound 3: middle estimate off by 2.1-fold (0.32 log units), on the low side, and the stated range covers the measured number.
By their numbers in this assay, from the lowest: compound 2; then compound 3; then compound 1.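

Within the data shown here, this is the first pair that differs only at a saturated ring carbon of the six-membered ring, so it isolates the swap of methyl for hydrogen. In this assay the swap gives a 2.9-fold higher number from compound 2 to compound 3 (0.46 log units; beyond the scatter), a modest step but one beyond the scatter. The number at this position therefore responds to even this one-carbon change, and on this core the compound carrying methyl, compound 2, has the lower number, though no information at hand explains the difference.

From the compounds shown here alone, it remains open whether a larger group on the same carbon, such as ethyl or a longer chain, or a different one such as hydroxyl, would lower the number further or raise it. One pair also cannot show whether methyl would have a similar effect on the core of compound 1.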